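This account rests on a few compounds, and the source may have more. Where it says the series, first, only, none or still open, it means among the compounds named here.

Compound 1, `COC(=O)CNC1=CS(=O)(=O)O[C@@]12[C@@H](CO[Si](C)(C)C(C)(C)C)O[C@@H](n1cc(C)c(=O)n(C)c1=O)[C@@H]2O[Si](C)(C)C(C)(C)C`: 96000 nM
Compound 2, `Cc1cn([C@@H]2O[C@@H]3COC4(O)CS(=O)(=O)O[C@@]34[C@H]2O)c(=O)[nH]c1=O`: 100000 nM

Of the compounds shown here, two have been measured in a functional assay on CCRF-CEM cells (Homo sapiens); a higher number here means that more compound is tolerated, a lower number that less compound is tolerated. Compound 1 gives 96000 nM, and compound 2 gives 100000 nM. These two numbers sit within the usual scatter of each other, so neither compound is set apart from the other on this read-out; both are tolerated by the cells up to very high concentrations.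

Compound 3, `Cc1cn([C@@H]2O[C@H](CO[Si](C)(C)C(C)(C)C)[C@@]3(OS(=O)(=O)C=C3NCC(=O)C(=O)O)[C@H]2O[Si](C)(C)C(C)(C)C)c(=O)n(C)c1=O`, has not yet been measured. It differs from compound 1 in one place: carboxy in place of methoxy on a carbonyl carbon. Going by the values given here, no pair of measured compounds shows what this kind of change does here, so there is no measured step to lean on. Among the compounds with values here, because the only measured compounds in this assay, compound 1 at 96000 nM and compound 2 at 100000 nM, both sit at the top of the tested range, the step of a 1.0-fold higher number from compound 1 to compound 3 (0.02 log units; within the scatter) is expected to be small, in no clear direction, and not beyond the scatter. Compound 3 is therefore estimated to give about 100000 nM in this assay, with a likely range from 40000 nM to 250000 nM.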

Compound 3, half-maximal cytotoxic concentration: 72600 nM
Compound 3: middle estimate off by 1.4-fold (0.14 log units), on the high side; the range from low to high includes it.
By their numbers in this assay, from the lowest: compounds 3, 1 and 2 (each within the scatter of the next).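

In this assay, going by these compounds alone, placing carboxy instead of methoxy on the carbonyl carbon gives a 1.3-fold lower number from compound 1 to compound 3 (0.12 log units; within the scatter), the first measured step at this position. This shows that the end of the ((methoxycarbonyl)methyl)amino chain can change from an ester-type methoxy group to carboxy, which by simple count brings one hydrogen-bond donor, without moving the read-out beyond the usual scatter, so the cells treat compound 1 and compound 3 alike on this measure. No measured evidence is available to explain this outcome.

The compounds shown leave open whether this lack of a clear step is particular to carboxy, or whether an amine, a hydroxyl group or a longer alkyl chain on the same carbonyl carbon would also stay within the scatter. They also leave open whether any change at this place can bring the number well below the values seen so far, or whether such a shift would have to come from elsewhere on the shared core.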